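Dimethylamino on the benzoyl ring of compound 3

The source may hold more compounds than are shown below. What is called first, only, known or untested is meant among the compounds shown, and "the series" means these compounds.

Measured in a functional assay on CAL-27 cells (Homo sapiens) for cytotoxicity, read by MTT assay, with a stated time of 72 h; on this read-out higher numbers stand for weaker inhibition and lower numbers for stronger inhibition:
Compound 1 `CN(C)c1ccc(C(=O)N(CCCCCC(=O)NO)CC(=O)NC2CCCCC2)cc1` gives 2970 nM
Compound 2 `CC(C)(C)NC(=O)CN(CCCCCC(=O)NO)C(=O)c1ccccc1` gives 16700 nM
Compound 3 `CC(C)(C(=O)NC1CCCCC1)N(CCCCCC(=O)NO)C(=O)c1ccccc1` gives 66900 nM

Compound 3 has the highest number of the three, beyond the scatter from both others. Compound 4 `CN(C)c1ccc(C(=O)N(CCCCCC(=O)NO)C(C)(C)C(=O)NC2CCCCC2)cc1` differs from it by dimethylamino in place of hydrogen on an aromatic carbon (dimethylamino in place of hydrogen on an aromatic carbon, para to a large group). Among the compounds with values here, no measured pair isolates this change. Compound 1, which carries the 4-(dimethylamino)phenyl group, gives 2970 nM as the lowest number, while compound 2 gives 16700 nM without it, but those two differ elsewhere as well. In this assay a moderate step of a 4.5-fold lower number from compound 3 to compound 4 (0.65 log units; beyond the scatter) is expected, toward stronger inhibition and beyond the scatter. Compound 4 is estimated at 15000 nM with 4000 nM to 45000 nM as the expected range.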

Compound 4, half-maximal inhibitory concentration: 47700 nM
Beside the measured number, compound 4's estimate is 3.2-fold (0.50 log units) below it; the whole stated range lies below it.
By their numbers in this assay, from the lowest: compound 1; then compound 2; then compounds 4 and 3 (each within the scatter of the next).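

In this assay, dimethylamino in place of hydrogen on an aromatic carbon, para to a large group, gives a 1.4-fold lower number from compound 3 to compound 4 (0.15 log units; within the scatter), so this change alone leaves the number within the scatter. Both carry dimethylamino, yet compound 1 gives 2970 nM and compound 4 gives 47700 nM, so the group's presence does not by itself go with the lowest number. Nothing at hand accounts for this result.

Open, from the compounds shown here alone, is whether methoxy or a carboxylic acid at this place would move the number. Also open, going by these compounds, is what dimethylamino does when the two methyl groups of compound 3 are absent.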